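The compounds below may be only part of what the source reports. "The series", "measured", "known", "first", "only" and "open" are said of these compounds alone.

Working notes on the series. All four compounds share one core, a five-membered aromatic ring with 1 nitrogen and 1 sulfur carrying a carboxymethyl group and a bis(4-fluorophenyl)methyl group; they differ only in the aryl group on the aromatic carbon next to the ring nitrogen. Compound 1 `O=C(O)Cc1sc(C(c2ccc(F)cc2)c2ccc(F)cc2)nc1-c1ccnc(N2CCC2)c1` gives 660 nM in an in vitro assay on HEK385-7 cells for displacement of a labelled ligand from prostaglandin D2 receptor 2 (Homo sapiens); a lower number here means a stronger inhibitor, a higher number a weaker inhibitor. Compound 2 `O=C(O)Cc1sc(C(c2ccc(F)cc2)c2ccc(F)cc2)nc1-c1ccco1` gives 18 nM, and compound 3 `NS(=O)(=O)c1cccc(-c2nc(C(c3ccc(F)cc3)c3ccc(F)cc3)sc2CC(=O)O)c1` gives 140 nM. Within the data shown here, compound 3 thus holds the second highest of the three numbers; the step of a 4.7-fold lower number from compound 1 to compound 3 (0.67 log units; beyond the scatter) is modest, and the step of a 7.8-fold higher number from compound 2 to compound 3 (0.89 log units; beyond the scatter) is also modest, while a 37-fold lower number from compound 1 to compound 2 (1.56 log units; beyond the scatter) is the one large step seen.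

Compound 4 `N#Cc1ccc(-c2nc(C(c3ccc(F)cc3)c3ccc(F)cc3)sc2CC(=O)O)cc1` has not been measured. The change is 4-cyanophenyl in place of 3-sulfamoylphenyl on an aromatic carbon. The two steps that bear on it, 1>3 and 2>3, both show that this aryl group moves the number modestly, with no measured case of a 4-cyanophenyl group at this carbon. A step of modest size in either direction is plausible; a number near that of compound 3, perhaps somewhat higher, is expected, a 1.6-fold higher number from compound 3 to compound 4 (0.20 log units; within the scatter). Compound 4 is estimated at 220 nM, with a range of 50 nM to 900 nM.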

Compound 4, half-maximal inhibitory concentration: 150 nM
Compound 4: middle estimate off by 1.5-fold (0.17 log units), on the high side, within the range that was stated.
By their numbers in this assay, from the lowest: compound 2; then compounds 3 and 4 (each within the scatter of the next); then compound 1.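

In this assay, 4-cyanophenyl in place of 3-sulfamoylphenyl gives a 1.1-fold higher number from compound 3 to compound 4 (0.03 log units; within the scatter), so this carbon tolerates this exchange of substituted phenyl groups, which differ in substituent, in its place on the phenyl ring and in hydrogen-bond donor count (0 against 1), without a change beyond the scatter. The other two steps, an 8.3-fold higher number from compound 2 to compound 4 (0.92 log units; beyond the scatter) and a 4.4-fold lower number from compound 1 to compound 4 (0.64 log units; beyond the scatter), repeat for the 4-cyanophenyl group the modest gaps already seen for 3-sulfamoylphenyl, leaving both phenyl compounds with numbers higher than that of compound 2 and lower than that of compound 1. Nothing available explains these steps or the lack of a step from the sulfonamide to the nitrile.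

The effects of the substituent and of its place on the phenyl ring remain unseparated, since a 3-cyanophenyl or 4-sulfamoylphenyl group would be needed to divide them. As far as these compounds go, how an unsubstituted phenyl or a thiophen-2-yl group at this carbon would compare with compound 2 also remains open.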